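A Smaller Chain End and Monoamine Oxidase Inhibition

This account rests on a few compounds, and the source may have more. Where it says the series, first, only, none or still open, it means among the compounds named here.

Measured so far:
compound 1, `CCOc1ccc2c(=O)c(-c3ccc(O)cc3)coc2c1`: 86.9%
compound 2, `O=c1c(-c2ccc(O)cc2)coc2cc(OCCC3OCCCO3)ccc12`: 57.6%

In a functional assay on mitochondria (Cricetulus griseus) for inhibition of Monoamine oxidase (Homo sapiens), tested at 0.9 uM (on this read-out lower numbers stand for a weaker effect and higher numbers for a stronger effect at the one concentration tested), compound 2 stands lowest of the two numbers, with compound 1 the nearest and higher. Going by the values given here, the one measured step, a number 29.3 percentage points lower from compound 1 to compound 2 (beyond the scatter), came with the six-membered ring group entering the chain. Compound 3, `O=c1c(-c2ccc(O)cc2)coc2cc(OCCCBr)ccc12`, now differs from compound 2 by a group of 2 heavy atoms (1 carbon, 1 bromine; no ring) in place of a group of 6 heavy atoms (4 carbon, 2 oxygen; one six-membered non-aromatic ring with 2 hetero atoms), on a saturated chain carbon, two bonds along the chain from an oxygen on an aromatic ring. Since that same ring group leaves again, this step bears directly on the new compound, and a rise of similar order is expected, though bromomethyl is not simply a hydrogen. Compound 3 is therefore estimated at 74% (range 55% to 90%), which means an expected a number 16.4 percentage points higher from compound 2 to compound 3 (beyond the scatter).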

Compound 3, a percentage reported as inhibition, at one concentration (the size of the read-out at that concentration, not a potency): 67.7%
For compound 3 the middle estimate is 6.3 percentage points above the measured one; the range from low to high includes it.
By their numbers in this assay, from the lowest: compound 2; then compound 3; then compound 1.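

In this assay the exchange of the ring group for bromomethyl gives a number 10.1 percentage points higher from compound 2 to compound 3 (beyond the scatter) and so brings back only part of what the ring group cost at this saturated chain carbon. Bromomethyl in place of hydrogen at the same place still gives a number 19.2 percentage points lower from compound 1 to compound 3 (beyond the scatter) and shows that a group without a ring also leaves the number short of compound 1. From the compounds shown here alone, whether an amine or a carboxylic acid on this chain would stand nearer compound 1 or compound 2 remains open, as does whether the bromine or the added carbon carries the gap to compound 1. No measurement shown here accounts for these differences.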